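A few compounds are considered here, and "the series" means these few. Any claim that something is new, unique, unknown or untested is made for them only; others in the source may bear on it.

Measured so far in an ADME assay on a cell-free system (plasma, Homo sapiens); on this read-out lower numbers stand for a smaller free fraction and higher numbers for a larger free fraction:
Compound 1 `CCNC(=O)Nc1nc2cc(-c3cccnc3)c(=O)n(CC)c2s1`: 0.11
Compound 2 `CCNC(=O)Nc1nc2cc(-c3cccnc3)c(=O)n(C(C)C)c2s1`: 0.21
Compound 3 `CCNC(=O)Nc1nc2cc(-c3cccnc3)c(=O)n(CCC(C)C)c2s1`: 0.06

Compound 3, at 0.06, lies within the scatter of compound 1 and clearly apart from compound 2. Compound 4 `CCNC(=O)Nc1nc2cc(-c3cccnc3)c(=O)n(CC3CCCCC3)c2s1` has not yet been measured. It carries cyclohexyl in place of isobutyl on a saturated chain carbon bound to an aromatic nitrogen, which also reads as isopentyl to cyclohexylmethyl. For the measured compounds named here, two steps bear on this change: a 1.8-fold lower number from compound 1 to compound 3 (0.26 log units; within the scatter) and a 3.5-fold lower number from compound 2 to compound 3 (0.54 log units; beyond the scatter). Going by the values given here, no measured compound has a ring in this place, so neither step is a direct precedent. A small further fall in this assay is expected, possibly none beyond the scatter. The estimated step is a 1.3-fold lower number from compound 3 to compound 4 (0.12 log units; within the scatter). Compound 4 is expected at 0.045, with an estimated range of 0.02 to 0.09.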

Compound 4, unbound fraction: 0.02
Compound 4: middle estimate off by 2.3-fold (0.35 log units), on the high side; measured number inside the range.
By their numbers in this assay, from the lowest: compound 4; then compounds 3, 1 and 2 (each within the scatter of the next, the first and the last beyond it).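

In this assay, the first ring at this position, cyclohexyl in place of isobutyl on a saturated chain carbon bound to an aromatic nitrogen, gives a 3.0-fold lower number from compound 3 to compound 4 (0.48 log units; beyond the scatter). Against the smaller groups, the steps are a 5.5-fold lower number from compound 1 to compound 4 (0.74 log units; beyond the scatter) and an 11-fold lower number from compound 2 to compound 4 (1.02 log units; beyond the scatter), so this position can move the free fraction well beyond the scatter. No evidence on the origin of these differences is available.

The compounds shown do not separate the ring from the added carbons, which a longer open chain could test. From the compounds shown here alone, how a benzyl group or a piperidinylmethyl group would behave here also remains open.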